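Amide side-chain variation on the shared core

The compounds below may be only part of what the source reports. "The series", "measured", "known", "first", "only" and "open" are said of these compounds alone.

Measured so far in a functional assay on HT-29 cells (Homo sapiens) for antiproliferative activity, read by MTT assay, with a stated time of 72 h, tested at 10 uM; on this read-out lower numbers stand for less inhibition and higher numbers for more inhibition at the one concentration tested (going by the name of the read-out):
compound 1 `CCn1cc(-c2ccc(F)cc2)c(=O)c2c(Nc3ccc(Oc4ccnc(NC(=O)C5CC5)c4)c(F)c3)nccc21` gives 15.8%
compound 2 `CC(O)C(=O)Nc1cc(Oc2ccc(Nc3nccc4[nH]cc(-c5ccc(F)cc5)c(=O)c34)cc2F)ccn1` gives 47.8%
compound 3 `CCCC(=O)Nc1cc(Oc2ccc(Nc3nccc4[nH]cc(-c5ccc(F)cc5)c(=O)c34)cc2F)ccn1` gives 23.5%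

Compound 2 stands highest of the three numbers; its nearest neighbour, compound 3, and the furthest, compound 1, both lie beyond the scatter below it. Among the compounds with values here, the only measured step touching the same part of the molecule is a number 24.3 percentage points lower from compound 2 to compound 3 (beyond the scatter), a replacement of the whole chain on the carbonyl carbon. Compound 4 `CC(C)(O)C(=O)Nc1cc(Oc2ccc(Nc3nccc4[nH]cc(-c5ccc(F)cc5)c(=O)c34)cc2F)ccn1` differs from compound 2 by methyl in place of hydrogen on a saturated chain carbon bound to a carbonyl carbon, an oxygen on a saturated carbon and a saturated chain carbon. Within the data shown here, this change is smaller than the one from compound 2 to compound 3: the oxygen on a saturated carbon stays and only a methyl is added, so a step of at most modest size is expected in this assay, more likely downward than upward. Compound 4 is therefore estimated at 40% (range 22% to 58%), corresponding to a number 7.8 percentage points lower from compound 2 to compound 4 (within the scatter).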

Compound 4, a percentage reported as inhibition, at one concentration (the size of the read-out at that concentration, not a potency): -2.9%
Compound 4: the middle estimate sits 42.9 percentage points above what was measured, and the stated range ends above it.
By their numbers in this assay, from the lowest: compound 4; then compounds 1 and 3 (each within the scatter of the next); then compound 2.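

In this assay, adding a single methyl on the saturated chain carbon bound to the carbonyl carbon gives a number 50.7 percentage points lower from compound 2 to compound 4 (beyond the scatter) in this series, so this position does not accept every small addition, even with the oxygen kept. Keeping that oxygen does not by itself secure a higher number either, as the exchange of propyl for 1-hydroxy-1-methylethyl gives a number 26.4 percentage points lower from compound 3 to compound 4 (beyond the scatter) on the same core. Nothing available accounts for this drop.

Going by these compounds, whether the drop is specific to the added methyl remains open. An amine or a methoxy on that same carbon, or an ethyl in place of the methyl, would help to settle this.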